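The source may hold more compounds than are shown below. What is called first, only, known or untested is meant among the compounds shown, and "the series" means these compounds.

Measured compounds:
- Compound 1, `O=C(Nc1cccc(-n2cc(-c3ccncc3)c(-c3ccc(Cl)c(O)c3)n2)c1)Nc1cccc(C(F)(F)F)c1` — a functional assay on HOP-62 cells (Homo sapiens) for inhibition, read by sulforhodamine B assay, with a stated time of 48 h; a higher number here means that more compound is tolerated, a lower number that less compound is tolerated: > 32500 nM
- Compound 2, `COc1cc(-c2nn(-c3cccc(NC(=O)Nc4cc(C(F)(F)F)cc(C(F)(F)F)c4)c3)cc2-c2ccncc2)ccc1Cl` — this assay: 2950 nM

Among the measured compounds shown here, compound 2 is the only compound with a numbered result in this assay, where it gives 2950 nM. For the measured compounds named here, for compound 1 the result is a limit of the assay rather than a number, > 32500 nM; it is the only other value shown, and it sits at that limit (the limit of > 32500 nM in this assay, at which 1 of the 2 values shown sits).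

Compound 3, `O=C(Nc1cccc(-n2cc(-c3ccncc3)c(-c3ccc(Cl)c(O)c3)n2)c1)Nc1cc(C(F)(F)F)cc(C(F)(F)F)c1`, has not yet been measured. It differs from compound 2 in one place: hydrogen in place of methyl on an oxygen on an aromatic ring, in words, hydrogen in place of methyl on an oxygen on an aromatic ring, so that methoxy becomes hydroxy and 4-chloro-3-methoxyphenyl becomes 4-chloro-3-hydroxyphenyl. Going by the values given here, no measured pair shows this change, so the size of the step is not known from these data. The estimated step from compound 2 to compound 3 is a 3.1-fold higher number from compound 2 to compound 3 (0.48 log units; beyond the scatter), a loss of tolerance because the hydroxy-bearing compound 1 reached only the limit > 32500 nM. Compound 3 is expected to give about 9000 nM, within 2500 nM to 32500 nM.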

Compound 3, concentration lethal to 50% of the cells: 4070 nM
Compound 3: the middle estimate sits 2.2-fold (0.34 log units) above what was measured, and the stated range covers the measured number.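

In this assay, changing 4-chloro-3-methoxyphenyl to 4-chloro-3-hydroxyphenyl makes little difference when the rest of the molecule stays the same: the result is a 1.4-fold higher number from compound 2 to compound 3 (0.14 log units; within the scatter). With the hydroxy kept, placing a trifluoromethyl on an aromatic carbon gives an at least 7.9-fold lower number from compound 1 to compound 3 (0.90 log units; beyond the scatter), so in compound 3 the hydroxy does not hold the compound at the limit reached by compound 1. That step gives only the smallest possible size, since the result for compound 1 is a limit of the assay and not a number: the limit of > 32500 nM in this assay, at which 1 of the 3 values shown sits.

On these data alone, it remains open whether an amine or an ethoxy group in this position would behave like methoxy and hydroxy. Also open, as far as these compounds go, is whether the trifluoromethyl step would have a similar size with methoxy in place of hydroxy.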